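The source may hold more compounds than are shown below. What is called first, only, known or untested is meant among the compounds shown, and "the series" means these compounds.

Three compounds have been measured in an ADME assay on Raji cells (Homo sapiens) for cytotoxicity, read by CellTiter-Glo and resazurin assay, with a stated time of 72 h (a lower number here means that less compound is needed, a higher number that more compound is needed for the effect), and each of them reached only the limit of the assay rather than a number:

Compound 1, `CCOC(=O)CCCCCOc1cccc(CN(C(=O)c2ccc(-c3cccnc3)cc2)C(C)C)c1`, gives the limit > 26000 nM.
Compound 2, `CCOC(=O)CCCCCOc1cccc(CN(C(=O)c2ccc(-c3cccc(OCc4ccccc4)c3)cc2)C(C)C)c1`, gives the limit > 26000 nM.
Compound 3, `CCOC(=O)CCCCCOc1cccc(CN(C(=O)c2ccc(-c3ccc4[nH]ccc4c3)cc2)C(C)C)c1`, gives the limit > 26000 nM.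

Compound 3 therefore stands where both of the others stand: at the limit, with no number that would set it apart from compound 1 or from compound 2. Going by the values given here, the single one-place step among the measured compounds, a step that the two limits leave unreadable from compound 1 to compound 3, cannot be read in size because of the limit of > 26000 nM in this assay, at which 3 of the 3 values shown sit.

Compound 4, `CCOC(=O)CCCCCOc1cccc(CN(C(=O)c2ccc(-c3cccc(Br)c3)cc2)C(C)C)c1`, is the compound still to be measured. It differs from compound 3 in one place: 3-bromophenyl in place of 1H-indol-5-yl on an aromatic carbon. Among the compounds with values here, no measured step bears on a change of this kind, and the only measured step is itself unreadable, so neither a size nor a direction can be drawn from the data. The expectation is that compound 4, like the three measured compounds, reaches the limit rather than a number. The step that the limit leaves unreadable from compound 3 to compound 4 is accordingly estimated as none beyond the scatter. In this assay compound 4 is expected to give about 40000 nM, within a range from 15000 nM to 150000 nM.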

Compound 4, half-maximal effective concentration: > 26000 nM
Compound 4: no number, only a limit; the forecaster's own chance of this, stated with the estimate: 85%; the middle value is on the limit's open side.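

No new step can be read between compound 4 and compound 1, compound 2 or compound 3, because all four compounds stop at the same limit: the limit of > 26000 nM in this assay, at which 4 of the 4 values shown sit. The compounds shown leave open how much of each is actually needed for the effect in this assay and whether any of these group changes alters that amount.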